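The source may hold more compounds than are shown below. What is called first, only, known or untested is meant among the compounds shown, and "the series" means these compounds.

Compound 1 `CCCC(O)C1=CC(=O)c2c(OC)ccc(OC)c2C1=O` gives 0.409 ug/mL in a functional assay on L1210 cells (Mus musculus) for cytotoxicity (on this read-out lower numbers stand for an effect already at smaller amounts and higher numbers for an effect only at larger amounts of compound), the highest number among the three measured compounds; compound 3 `CCCCCCCC(O)c1cc(OC)c2c(c1OC)C(=O)C=CC2=O` gives 0.274 ug/mL, a gap within the scatter, while compound 2 `COc1cc(CO)c(OC)c2c1C(=O)C=CC2=O` gives 0.062 ug/mL, a gap beyond it. Compound 4 `CCCCCCCC(O)C1=CC(=O)c2c(OC)ccc(OC)c2C1=O` differs from compound 1 by butyl in place of hydrogen on a saturated chain carbon, four bonds along the chain from a double-bonded ring carbon and an oxygen on a saturated carbon. Among the compounds with values here, the one measured step that bears on lengthening the chain at this saturated carbon is a 4.4-fold higher number from compound 2 to compound 3 (0.65 log units; beyond the scatter), which went from hydrogen to heptyl on the core of compound 2; here the chain already carries propyl and grows to heptyl, so a smaller shift is expected. The step from compound 1 to compound 4 is therefore expected to read a 1.3-fold higher number from compound 1 to compound 4 (0.13 log units; within the scatter), likely within the scatter or a little higher. Compound 4 is estimated at 0.55 ug/mL, within 0.22 ug/mL to 1.4 ug/mL.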

Compound 4, concentration for half-maximal effect: 1.04 ug/mL
Compound 4: middle estimate off by 1.9-fold (0.28 log units), on the low side, within the range that was stated.
By their numbers in this assay, from the lowest: compound 2; then compounds 3 and 1 (each within the scatter of the next); then compound 4.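

Propyl to heptyl at this saturated chain carbon gives a 2.5-fold higher number from compound 1 to compound 4 (0.41 log units; beyond the scatter) in this assay, so chain growth alone moves the number beyond the scatter on the core of compound 1, even with propyl already in place. Together with a 4.4-fold higher number from compound 2 to compound 3 (0.65 log units; beyond the scatter), on another core, both listed steps run the same way, with no compound shown going against them.

On these data alone, whether a chain longer than heptyl, or an amine on this carbon, would continue the rise stays open. No measured evidence accounts for the shift.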